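The source may hold more compounds than are shown below. What is called first, only, known or untested is meant among the compounds shown, and "the series" means these compounds.

Measured so far in an assay on CHO cells for antagonist activity at transient receptor potential cation channel subfamily V member 1 (Homo sapiens), read by FLIPR; a higher number here means a weaker inhibitor, a lower number a stronger inhibitor:
- compound 1, `CC(C(=O)NCc1ccc(C(F)(F)F)nc1-c1ccc(N(C)C)cc1)c1ccc(NS(C)(=O)=O)c(F)c1` — compound 1 gives 3.2 nM
- compound 2, `CC(C(=O)NCc1ccc(C(F)(F)F)nc1-c1ccc(F)c(Cl)c1)c1ccc(NS(C)(=O)=O)c(F)c1` — compound 2 gives 0.2 nM
- compound 3, `COc1ccc(-c2nc(C(F)(F)F)ccc2CNC(=O)C(C)c2ccc(NS(C)(=O)=O)c(F)c2)cc1F` — compound 3 gives 4.2 nM

Compound 3 has the highest of the three numbers in this assay. Against compound 1 it stands a 1.3-fold higher number from compound 1 to compound 3 (0.12 log units; within the scatter), so the two are not separated; against compound 2 it stands a 21-fold higher number from compound 2 to compound 3 (1.32 log units; beyond the scatter), a clear gap.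

Compound 4, `CC(C(=O)NCc1ccc(C(F)(F)F)nc1Cc1ccccc1)c1ccc(NS(C)(=O)=O)c(F)c1`, differs from compound 3 at the same position that varies across the three measured compounds: benzyl in place of 3-fluoro-4-methoxyphenyl on an aromatic carbon. The measured steps at this position are a 16-fold lower number from compound 1 to compound 2 (1.20 log units; beyond the scatter), a 1.3-fold higher number from compound 1 to compound 3 (0.12 log units; within the scatter) and a 21-fold higher number from compound 2 to compound 3 (1.32 log units; beyond the scatter). Within the data shown here, they show that this position can move the number by a large amount, but none of them exchanges an aromatic ring attached directly for a benzyl group, so no measured step bears on the change itself. The spread already seen among compounds 1, 2 and 3 argues for a wide range rather than a tight one, and the loss of the acceptor counted in the difference gives no direction that the data support.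

Compound 4 is expected to give about 10 nM in this assay, with a likely range from 2 nM to 60 nM; the expected step is a 2.4-fold higher number from compound 3 to compound 4 (0.38 log units; beyond the scatter).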

Compound 4, inhibition constant: 141 nM
Beside the measured number, compound 4's estimate is 14-fold (1.15 log units) below it; the measured number lies above the stated range.
By their numbers in this assay, from the lowest: compound 2; then compounds 1 and 3 (each within the scatter of the next); then compound 4.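

In this assay the benzyl group, on the aromatic carbon next to the ring nitrogen, gives compound 4 a number beyond the scatter of all three directly attached phenyl rings, and the exchanges all run the same way, with none against them: a 34-fold higher number from compound 3 to compound 4 (1.53 log units; beyond the scatter) and a 44-fold higher number from compound 1 to compound 4 (1.64 log units; beyond the scatter) and a 710-fold higher number from compound 2 to compound 4 (2.85 log units; beyond the scatter). The widest step among the phenyl rings alone is a 21-fold higher number from compound 2 to compound 3 (1.32 log units; beyond the scatter) and the range at this position is now wider than those compounds showed, with compound 4 the weakest inhibitor of the four. Nothing measured here gives a reason for this loss.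

Compound 4 differs from the other compounds both in the carbon link and in the lack of ring substituents, so the compounds shown leave open which of the two carries the step; an unsubstituted phenyl ring attached directly, or a benzyl group carrying the chlorine and fluorine of compound 2, would separate them. Also open, from the compounds shown here alone, is how a phenethyl chain or a phenylamino link would read at this position.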